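The source may report more compounds than this note shows. Statements on the series, on what has been measured and on what is new or still open speak of the compounds shown alone.

Values measured in a functional assay on KBVIN cells (Homo sapiens) for antiproliferative activity, read by sulforhodamine B assay, with a stated time of 3 days; on this read-out lower numbers stand for an effect already at smaller amounts and higher numbers for an effect only at larger amounts of compound:

- compound 1 `CCOc1ccc(-c2cc(=O)c3c(o2)C(CC)(CC)C(=O)C(CC)=C3O)cc1`: 7.54 uM
- compound 2 `CCC1=C(O)c2c(oc(-c3ccc(C)c(C)c3)cc2=O)C(CC)(CC)C1=O`: 0.71 uM
- compound 3 `CCC1=C(O)c2c(oc(-c3ccc(C)c(F)c3)cc2=O)C(CC)(CC)C1=O`: 2.95 uM

Among these three numbers, compound 3 is the second highest. Compound 4 `CCC1=C(O)c2c(oc(-c3ccc(OC)c(F)c3)cc2=O)C(CC)(CC)C1=O` differs from it by methoxy in place of methyl on an aromatic carbon, with methoxy in place of methyl on an aromatic carbon. The nearest evidence comes from the ethoxy-bearing compound 1. Changing 4-ethoxyphenyl to 3-fluoro-4-methylphenyl gave a 2.6-fold lower number from compound 1 to compound 3 (0.41 log units; beyond the scatter), a modest step. Fluoro in place of methyl gave a 4.2-fold higher number from compound 2 to compound 3 (0.62 log units; beyond the scatter), also modest, and an 11-fold lower number from compound 1 to compound 2 (1.03 log units; beyond the scatter) was large. A modest move to a higher number is therefore expected in this assay. The expected step is a 1.5-fold higher number from compound 3 to compound 4 (0.18 log units; within the scatter). For compound 4 the estimated value is 4.5 uM, with an expected range of 1.8 uM to 11 uM.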

Compound 4, concentration for half-maximal effect: 0.1 uM
The estimate for compound 4 lay 45-fold (1.65 log units) above the measured number; measured number outside the range, below it.
By their numbers in this assay, from the lowest: compound 4; then compound 2; then compound 3; then compound 1.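

In this assay, within the data shown here, with the fluoro group kept, methoxy in place of methyl gave a 30-fold lower number from compound 3 to compound 4 (1.47 log units; beyond the scatter), so this carbon responds far more strongly than the earlier compounds suggested. The 3-fluoro-4-methoxyphenyl group also gave a 7.1-fold lower number from compound 2 to compound 4 (0.85 log units; beyond the scatter) and a 75-fold lower number from compound 1 to compound 4 (1.88 log units; beyond the scatter), leaving compound 4 with the lowest number of the four. Oxygen on this carbon does not guarantee a low number, as compound 1, with 4-ethoxyphenyl, stands highest.

Nothing shown accounts for this large gain. From the compounds shown here alone, whether it persists without the fluoro group, or with a hydroxy group or an amine on this carbon, remains open.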